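The compounds below may be only part of what the source reports. "The series", "measured", "known", "first", "only" and "open" are said of these compounds alone.

Measured in an assay on isolated protein for inhibition of histone deacetylase HD2 (Zea mays) (a lower number here means a stronger inhibitor, a higher number a weaker inhibitor), so far:
compound 1 `O=C(/C=C/c1cccc(CSc2nc(O)cc(-c3ccccc3)n2)c1)NO` gives 17 nM
compound 2 `CC(c1ccccc1)c1cc(O)nc(SCCCCCC(=O)NO)n1` gives 9 nM

Compound 1 holds the higher of the two numbers in this assay; the nearest is compound 2, whose value lies within the scatter of it, so the two show no separable order. Among the measured compounds shown here, the two structures differ in more than one place, so no single step between them is counted.

Compound 3 `O=C(/C=C/c1cccc(CSc2nc(O)cc(Cc3ccccc3)n2)c1)NO` is the next compound for this assay. Against compound 1 it carries benzyl in place of phenyl on an aromatic carbon, benzyl in place of phenyl on an aromatic carbon. For the measured compounds named here, no measured pair shows this change, and nothing in the two numbers in hand speaks for a step beyond the scatter in either direction; the working expectation is a number close to that of compound 1 17 nM, with a slight lean toward a higher one. Compound 3 is therefore expected at 20 nM, within 7 nM to 60 nM. The step is estimated as a 1.2-fold higher number from compound 1 to compound 3 (0.07 log units; within the scatter).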

Compound 3, half-maximal inhibitory concentration: 41 nM
The estimate for compound 3 lay 2.1-fold (0.31 log units) below the measured number; low and high end bracket the measured number.
By their numbers in this assay, from the lowest: compounds 2 and 1 (each within the scatter of the next); then compound 3.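

Benzyl in place of phenyl on an aromatic carbon gives a 2.4-fold higher number from compound 1 to compound 3 (0.38 log units; beyond the scatter) in this assay and is the first readable step in the series, so this position, next to the ring nitrogen, does respond to substitution. The change is small by count: the entering group adds one carbon to the phenyl group, keeps the six-membered aromatic ring of carbon only, and has no hydrogen-bond donors or acceptors. No measured evidence bears on the reason for this step.

As far as these compounds go, whether a longer chain, such as phenylethyl, would move the number further at this position remains open, as does the effect of an amine on the ring. A single pair also cannot show whether this step carries over to other cores.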